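This account rests on a few compounds, and the source may have more. Where it says the series, first, only, none or still open, it means among the compounds named here.

Compounds measured so far in a functional assay on Bel-7402 cells (Homo sapiens) for cytotoxicity, read by MTT assay, with a stated time of 24 h; a higher number here means a weaker inhibitor, a lower number a stronger inhibitor:

Compound 1, `COC(=O)[C@@H](CC(C)C)NC(=O)Cn1cc(C2=C(c3c[nH]c4ccccc34)C(=O)N(C)C2=O)c2ccccc21`: 42400 nM
Compound 2, `COC(=O)[C@@H](CO)NC(=O)Cn1cc(C2=C(c3c[nH]c4ccccc34)C(=O)N(C)C2=O)c2ccccc21`: 67200 nM
Compound 3, `COC(=O)[C@H](NC(=O)Cn1cc(C2=C(c3c[nH]c4ccccc34)C(=O)N(C)C2=O)c2ccccc21)C(C)C`: 4010 nM

Among these three numbers compound 1 gives the second highest, though the step to compound 2 a 1.6-fold higher number from compound 1 to compound 2 (0.20 log units; within the scatter) does not separate the two, while the step to compound 3 an 11-fold lower number from compound 1 to compound 3 (1.02 log units; beyond the scatter) is large and well beyond the scatter. The step from compound 2 to compound 3 a 17-fold lower number from compound 2 to compound 3 (1.22 log units; beyond the scatter) is larger still.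

Compound 4, `COC(=O)CC[C@@H](NC(=O)Cn1cc(C2=C(c3c[nH]c4ccccc34)C(=O)N(C)C2=O)c2ccccc21)C(=O)OC`, is the next member of the series. It differs from compound 1 by (methoxycarbonyl)methyl in place of isopropyl on a saturated chain carbon, two bonds along the chain from an amide-type nitrogen and a carbonyl carbon.

Going by the values given here, the steps that bear on this are those at the same side chain. Among the compounds with values here, the one change made on a saturated chain carbon, two bonds along the chain from an amide-type nitrogen and a carbonyl carbon, hydroxy in place of isopropyl, stayed within the scatter. The large steps arose only when the group on the saturated chain carbon bound to an amide-type nitrogen and a carbonyl carbon was shortened to isopropyl, which is not what happens here. Compound 4 is therefore expected to show no step beyond the scatter in this assay, a 1.2-fold higher number from compound 1 to compound 4 (0.07 log units; within the scatter), with the estimate 50000 nM and a range of 20000 nM to 130000 nM.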

Compound 4, half-maximal inhibitory concentration: 47400 nM
Estimate against measurement, compound 4: 1.1-fold (0.02 log units) above; low and high end bracket the measured number.
By their numbers in this assay, from the lowest: compound 3; then compounds 1, 4 and 2 (each within the scatter of the next).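

At the saturated chain carbon two bonds along the chain from an amide-type nitrogen and a carbonyl carbon, (methoxycarbonyl)methyl in place of isopropyl gives a 1.1-fold higher number from compound 1 to compound 4 (0.05 log units; within the scatter) in this assay and, in place of hydroxy, a 1.4-fold lower number from compound 2 to compound 4 (0.15 log units; within the scatter); isopropyl carries 0 hydrogen-bond acceptors and (methoxycarbonyl)methyl carries 2, yet the three groups at this place are not separated here. On the saturated chain carbon bound to an amide-type nitrogen and a carbonyl carbon, 2-(methoxycarbonyl)ethyl in place of isopropyl gives a 12-fold higher number from compound 3 to compound 4 (1.07 log units; beyond the scatter), so compound 3 now stands apart, beyond the scatter, from all three other compounds. The compounds shown come with no separate measurement that would account for either finding.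

As far as these compounds go, it remains open whether a carboxylic acid in place of the methyl ester at the end of the chain, or an amine there, would also leave the number unchanged within the scatter. From the compounds shown here alone, it is also open whether a tert-butyl or a cyclohexyl group on the saturated chain carbon bound to the amide-type nitrogen and the carbonyl carbon would fall with compound 3 or with the other three.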